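A few compounds are considered here, and "the series" means these few. Any claim that something is new, unique, unknown or untested is made for them only; others in the source may bear on it.

Measured so far in a functional assay on A549 cells (Homo sapiens) for antiproliferative activity, read by MTT assay, with a stated time of 72 h; a higher number here means a weaker inhibitor, a lower number a stronger inhibitor: compound 1 `CCCCCCCNC(=N)NC(=N)Nc1ccc(F)c(F)c1` gives 1500 nM; compound 2 `CC(C)CNC(=N)NC(=N)Nc1ccc(C(F)(F)F)cc1` gives 1300 nM; compound 3 `N=C(NC(=N)NC1CCCC1)Nc1ccc(F)cc1F` gives 4000 nM.

Compound 1 stands second highest of these three numbers. Its nearest neighbour is compound 2, whose number lies within the scatter of its own, so no order can be claimed between them; its furthest is compound 3, whose higher number lies beyond the scatter. Compound 4 `N=C(NC(=N)NC1CCCC1)Nc1ccc(F)c(F)c1` has not yet been measured in this assay. It differs from compound 1 in one place: cyclopentyl in place of heptyl on an amine nitrogen. Because compound 3 with its cyclopentyl group gives 4000 nM, the step is expected to be a 2.1-fold higher number from compound 1 to compound 4 (0.33 log units; beyond the scatter), toward a higher number and beyond the scatter. Compound 4 is therefore expected to give about 3200 nM, within a range from 1300 nM to 7500 nM.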

Compound 4, half-maximal inhibitory concentration: 3500 nM
The estimate for compound 4 lay 1.1-fold (0.04 log units) below the measured number; the range from low to high includes it.
By their numbers in this assay, from the lowest: compounds 2 and 1 (each within the scatter of the next); then compounds 4 and 3 (each within the scatter of the next).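

Exchanging heptyl for cyclopentyl on this amine nitrogen, with the rest of the core unchanged, gives a 2.3-fold higher number from compound 1 to compound 4 (0.37 log units; beyond the scatter) in this assay, a modest step. This is the first pair shown that differs in one place, and it shows that the number responds to the group at this position. No supporting measurement is available to explain the step.

The compounds shown leave open how a cyclohexyl or a benzyl group on this nitrogen would compare with heptyl and cyclopentyl.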